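Chloro in place of hydrogen: tolerance of compound 4

The compounds below may be only part of what the source reports. "The series", "measured", "known", "first", "only" and "open" are said of these compounds alone.

Compound 1 `Cc1ccccc1-c1nn(-c2ccc(F)cc2F)cc1CNCCN1CCCCC1`: in an ADME assay on Huh-7 cells (Homo sapiens) for cytotoxicity (a lower number here means that less compound is tolerated, a higher number that more compound is tolerated), a limit only, > 20000 nM.
Compound 2 `CN1CCN(CCNCc2cn(-c3ccc(F)cc3F)nc2-c2ccccc2)CC1`: in this assay a limit only, > 20000 nM.
Compound 3 `Cc1c(CNCCN2CCN(C)CC2)c(-c2ccccc2)nn1-c1ccc(F)cc1`: in this assay a limit only, > 20000 nM.

Compound 2 thus stands at a limit rather than a number in this assay, and the two other values are limits as well: the limit of > 20000 nM in this assay, at which 3 of the 3 values shown sit. Compound 4 `CN1CCN(CCNCc2cn(-c3ccc(F)cc3F)nc2-c2cccc(Cl)c2)CC1` differs from compound 2 by chloro in place of hydrogen on an aromatic carbon. Going by the values given here, no step between two measured compounds is available to size this change. The step from a step that the limit leaves unreadable from compound 2 to compound 4 is expected to stay within the scatter, in no clear direction. Compound 4 is expected to give 25000 nM in this assay, somewhere between 10000 nM and 60000 nM, most probably again only as a limit.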

Compound 4, half-maximal cytotoxic concentration: 15000 nM
The estimate for compound 4 lay 1.7-fold (0.22 log units) above the measured number; measured number inside the range.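

Alone among the compounds shown, compound 4 gives a number rather than a limit in this assay, so the change from phenyl to 3-chlorophenyl can now be given a size: an at least 1.3-fold lower number from compound 2 to compound 4 (0.12 log units; that floor lies within the scatter). This is only a floor, and it does not show an effect of chloro at this position beyond the scatter. The true size stays unread because compound 2 stands at a limit, as most of the series does: the limit of > 20000 nM in this assay, at which 3 of the 4 values shown sit.

The compounds shown leave open whether methyl, methoxy or trifluoromethyl in the same place would give a similar number. They also leave open how an amine there would compare.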